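Methyl in place of nitro: cytotoxicity note

This account rests on a few compounds, and the source may have more. Where it says the series, first, only, none or still open, it means among the compounds named here.

Three compounds of the series have readings in an ADME assay on MDBK cells (Bos taurus) for cytotoxicity, read by MTT assay, with a stated time of 96 h; on this read-out higher numbers stand for lower toxicity in this test and lower numbers for higher toxicity in this test. Compound 1 `CN(C)CCCNc1ccc(/N=N/c2ccc([N+](=O)[O-])cc2)cc1` returns only a limit of the assay in this assay, > 100000 nM, so its position is a bound rather than a number. Compound 2 `FC(F)(F)c1cccc(/N=N/c2ccc(NC[C@@H]3CCCN4CCCC[C@H]34)c3c2CCCC3)c1` gives 30000 nM in this assay. Compound 3 `CN(C)CCCN(/N=N/c1cc(F)ccc1F)c1ccccc1` gives 25000 nM in this assay. Compound 1 thus sits at the edge of what the test reports (the limit of > 100000 nM in this assay, at which 1 of the 3 values shown sits), while compound 2 and compound 3 return numbers inside the measured range.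

Compound 4 `Cc1ccc(/N=N/c2ccc(NCCCN(C)C)cc2)cc1` is not yet measured. It differs from compound 1 in one place: methyl in place of nitro on an aromatic carbon. Among the compounds with values here, no measured pair changes a single substituent on an aromatic carbon, so no measured step speaks directly to this change. Compound 1 gives only a limit (the limit of > 100000 nM in this assay, at which 1 of the 3 values shown sits), so any numbered result for compound 4 could appear only toward higher toxicity. The expected step in this assay is none beyond the scatter, with at most a small shift toward higher toxicity. The estimate for compound 4 in this assay is 100000 nM, with a range from 40000 nM to 300000 nM. The expected step of a number no higher from compound 1 to compound 4 (the limit leaves the size open) stays within scatter of the limit, and a repeat limit rather than a number is the more likely outcome.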

Compound 4, half-maximal cytotoxic concentration: > 100000 nM
Compound 4: no number, only a limit; the forecaster's own chance of this, stated with the estimate: 60%; the middle value sits exactly at the limit.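

In this assay compound 4 returns only a limit (> 100000 nM). Compound 1 also returns only a limit (> 100000 nM), so no step can be read between these two compounds. The compounds shown leave open whether methyl in place of nitro on an aromatic carbon changes toxicity in this test at all.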